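Enantiomer of compound 2 in the potassium channel series

This account rests on a few compounds, and the source may have more. Where it says the series, first, only, none or still open, it means among the compounds named here.

Working notes on a set of benzamides read in an assay for activation of potassium voltage-gated channel subfamily KQT member 1 (Cavia porcellus); a lower number here means a stronger inhibitor, a higher number a weaker inhibitor. Compound 1, `CCCCCCOc1ccc(C(=O)NC2CCCC2(C)C)cc1`, gives only a limit of the assay, > 30000 nM; the entry the limit of > 30000 nM in this assay, at which 1 of the 3 values shown sits, records it as such. Compound 3, `CC(C)(C)CCNC(=O)c1ccc(-n2ccc3ccccc32)cc1`, gives 260 nM in this assay. Compound 2, `CCCCc1noc(-c2ccc(C(=O)NC[C@@H]3CCCC3(C)C)cc2)n1`, gives 9 nM in this assay, the lowest of the two numbers reported; its gap to compound 3 lies beyond the usual scatter. The remaining entry in the set, that of compound 1, is a limit rather than a number.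

The next compound, compound 4, `CCCCc1noc(-c2ccc(C(=O)NC[C@H]3CCCC3(C)C)cc2)n1`, is the mirror form of compound 2: the two compounds have the same atoms and bonds and differ only in configuration as drawn: 1 of 1 stereo elements differ; a stereocentre at a saturated ring carbon is drawn R in compound 2 and S in compound 4. No pair of measured compounds in the set differs only in configuration, so the size of this step has no precedent among the numbers shown, and nothing in the set tells which configuration is preferred. Since compound 2 already holds the lowest number present, the step is expected to run toward a higher number rather than a lower one, and the expected step from compound 2 to compound 4 is a 6.7-fold higher number from compound 2 to compound 4 (0.82 log units; beyond the scatter). Compound 4 is estimated to give 60 nM in this assay, within a range from 9 nM to 600 nM.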

Compound 4, half-maximal inhibitory concentration: 2 nM
Estimate against measurement, compound 4: 30-fold (1.48 log units) above, and the stated range ends above it.
By their numbers in this assay, from the lowest: compound 4; then compound 2; then compound 3. At a limit, above all of these: compound 1.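

Drawing the stereocentre at a saturated ring carbon as S rather than R gives, in this assay, a 4.5-fold lower number from compound 2 to compound 4 (0.65 log units; beyond the scatter), so within this pair the S form is the preferred one. The step can be assigned to configuration alone, because no atom or bond changes between the two compounds: the fact that compounds 2 and 4 differ only in the configuration as drawn. The earlier compounds shown here offered no pair of this kind, and this one shows that configuration at this ring carbon is a variable in its own right, of modest size here, and that the number held by compound 2 was not the lowest this series could reach.

This is a single step at a single stereocentre, so it says nothing yet about whether the S preference belongs to the shared core in general or only to this particular pair. From the compounds shown here alone, whether the same preference and a similar step size would hold with a carboxylic acid, an amine or a longer chain in place of the butyl chain remains open, as does the effect of removing one or both methyl groups from the saturated ring.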